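The source may report more compounds than this note shows. Statements on the series, on what has been measured and on what is new or still open speak of the compounds shown alone.

In an ADME assay on Vero cells (Chlorocebus sabaeus) for cytotoxicity, read by neutral red uptake, with a stated time of 48 h (a higher number here means a weaker inhibitor, a lower number a stronger inhibitor), compound 3 `CCN(CC)c1nc(Cl)nc2c1ncn2CCCNc1ccnc2cc(Cl)ccc12` gives > 10700 nM, which is a limit of the assay and not a number. Compound 1 `CN(C)c1nc(Cl)nc2c1ncn2CCNc1ccnc2cc(Cl)ccc12` also gives only a limit, > 11800 nM. Compound 2 `Clc1ccc2c(NCCn3cnc4c(N5CCN(c6ccccc6)CC5)nc(Cl)nc43)ccnc2c1` gives a true number, 4040 nM. As far as these compounds go, compound 3 therefore stands among the two limits, and its actual position on the scale is unknown.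

Compound 4 `Clc1ccc2c(NCCCn3cnc4c(N5CCCCC5)nc(Cl)nc43)ccnc2c1` carries piperidin-1-yl in place of diethylamino on an aromatic carbon. For the measured compounds named here, one measured step bears on a change at this place: an at least 2.9-fold lower number from compound 1 to compound 2 (0.46 log units; beyond the scatter). That step brought in 4-phenylpiperazin-1-yl, with its added phenyl ring, while the present change only closes a similar amine into a ring. It also comes from a pair that differs from compound 3 elsewhere, so it is a loose guide. Given the size of an at least 2.9-fold lower number from compound 1 to compound 2 (0.46 log units; beyond the scatter), a step of that full size is not expected in this assay. A small shift towards a lower number is expected at most, possibly none beyond the scatter, and compound 4 may again return only a limit.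

For compound 4 the expected value is 8000 nM, with an estimated range of 3000 nM to 16000 nM. The estimated step is an at least 1.3-fold lower number from compound 3 to compound 4 (0.12 log units; that floor lies within the scatter).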

Compound 4, half-maximal inhibitory concentration: > 10400 nM
Compound 4 gave a limit, no number (the forecaster's own chance of this, stated with the estimate: 50%); middle value at least 1.3-fold (0.11 log units) away from the limit.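

In this assay compound 4 gives > 10400 nM, which is a limit of the assay and not a number. For the compounds shown here, compound 3 also gives only a limit, so no step between compound 3 and compound 4 can be read. The compounds shown leave open whether piperidin-1-yl in place of diethylamino on an aromatic carbon changes the value at all.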